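The source may report more compounds than this note shows. Statements on the series, on what has been measured and on what is new or still open speak of the compounds shown alone.

Of the compounds shown here, three built on one shared core have so far been tested in an ADME assay on Vero cells (Chlorocebus sabaeus) for cytotoxicity, read by MTT assay, with a stated time of 72 h; on this read-out higher numbers stand for lower toxicity in this test and lower numbers for higher toxicity in this test. Compound 1 `O=C(C1CC1)N1CCN(c2nc(=O)c3cc(C(F)(F)F)cc([N+](=O)[O-])c3s2)CC1` carries a cyclopropyl group on the carbonyl carbon of its amide. In this assay compound 1 returns > 125000 nM, which is a limit of the assay and not a number. Compound 2 `O=C(C1CCCCC1)N1CCN(c2nc(=O)c3cc(C(F)(F)F)cc([N+](=O)[O-])c3s2)CC1` carries a cyclohexyl group in that place, and in this assay compound 2 gives 88700 nM. Compound 3 `CC(C)CC(=O)N1CCN(c2nc(=O)c3cc(C(F)(F)F)cc([N+](=O)[O-])c3s2)CC1` carries an isobutyl group there. In this assay compound 3 returns > 125000 nM, again a limit rather than a number, so compound 3 stands where the test stops reporting, as described by the limit of > 125000 nM in this assay, at which 2 of the 3 values shown sit.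

The measured steps are small or unreadable: an at least 1.4-fold lower number from compound 1 to compound 2 (0.14 log units; that floor lies within the scatter); an at least 1.4-fold higher number from compound 2 to compound 3 (0.14 log units; that floor lies within the scatter); and a step that the two limits leave unreadable from compound 1 to compound 3. None of them reaches beyond the usual scatter.

Compound 4 `O=C(C1CCC1)N1CCN(c2nc(=O)c3cc(C(F)(F)F)cc([N+](=O)[O-])c3s2)CC1` differs from compound 3 in one place: cyclobutyl in place of isobutyl on a carbonyl carbon. The step from cyclohexyl to isobutyl and from cyclopropyl to cyclohexyl each changed little, so the expected step is a step that the limit leaves unreadable from compound 3 to compound 4, that is, none beyond the scatter. Compound 4 is therefore estimated at 140000 nM in this assay, with a range from 80000 nM to 250000 nM, and most likely only a limit will again be reported.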

Compound 4, half-maximal cytotoxic concentration: > 125000 nM
Compound 4 ended at the assay's limit; the forecaster's own chance of this, stated with the estimate: 70%; the middle value does not contradict the limit.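

Closing the open isobutyl chain into a cyclobutyl ring, with the same 4 carbon atoms, adds a new ring size at this position on the carbonyl carbon, yet in this assay compound 4 gives only a limit of the assay and not a number. Among these compounds, the steps to compound 4 from compound 3 and from compound 1 therefore cannot be read, and the one readable step is an at least 1.4-fold higher number from compound 2 to compound 4 (0.14 log units; that floor lies within the scatter), so the cyclobutyl group is not clearly set apart even from the cyclohexyl group. With an open chain and rings of three sizes now tested on this carbonyl carbon, the result adds a further case at the ceiling of the test: the limit of > 125000 nM in this assay, at which 3 of the 4 values shown sit.

As far as these compounds go, how far compounds 1, 3 and 4 lie past that limit remains unknown, so any differences among them stay hidden. Also open, from the compounds shown here alone, is how a different kind of group on this carbonyl carbon, such as an amine, a carboxylic acid or a longer chain, would read in this assay.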